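Mirror Image of Compound 1: Expected Inhibition

The source may report more compounds than this note shows. Statements on the series, on what has been measured and on what is new or still open speak of the compounds shown alone.

Compound 1 `O=C(O)[C@@H]1NCC=C[C@@H]1O` is the starting point. In an assay for inhibition of alpha-N-acetylgalactosaminidase (Gallus gallus), tested at 1000 uM (a lower number here means less inhibition, a higher number more inhibition at the concentration tested (going by the name of the read-out)), compound 1 gives 1.3%. Two further compounds have been measured alongside it: compound 2 `O=C(O)[C@H]1NC[C@H](O)[C@H](O)[C@@H]1O` gives 4.5% in this assay, and compound 3 `O=C(O)[C@@H]1NC[C@@H](O)[C@H](O)[C@H]1O` gives 1.3%. Compound 1 stands level with compound 3 at the digits shown, and the number for compound 2 lies within the scatter of it, so the three measured compounds cannot be told apart on these readings.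

Compound 4 `O=C(O)[C@H]1NCC=C[C@H]1O` is the compound not yet measured. the two compounds have the same atoms and bonds and differ only in configuration as drawn: 2 of 2 stereo elements differ (all stereocentres are inverted: mirror images); a stereocentre at a saturated ring carbon is drawn R in compound 1 and S in compound 4; a stereocentre at a saturated ring carbon is drawn S in compound 1 and R in compound 4

One measured step speaks to this kind of change. Compounds 2 and 3 are related by configuration alone (the fact that compounds 2 and 3 differ only in the configuration as drawn), and the step of a number 3.2 percentage points lower from compound 2 to compound 3 (within the scatter) remained within the scatter, so there a change of configuration by itself did not move the read-out beyond what repeated measurements give. Going from compound 1 to compound 4 inverts every stereocentre rather than some of them, but with only that single step to go on, no change beyond the scatter is expected for compound 4 in this assay. Compound 4 is therefore estimated at 2%, within a range of 0% to 12%. That estimate means an expected step of a number 0.7 percentage points higher from compound 1 to compound 4 (within the scatter).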

Compound 4, a percentage reported as inhibition, at one concentration (the size of the read-out at that concentration, not a potency): 0.2%
Compound 4: the middle estimate sits 1.8 percentage points above what was measured, and the stated range covers the measured number.
By their numbers in this assay, from the lowest: compounds 4, 1, 3 and 2 (each within the scatter of the next).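

In this assay the mirror-image pair shows a number 1.1 percentage points lower from compound 1 to compound 4 (within the scatter), so the two compounds cannot be told apart on this reading. The earlier pair of compounds inverted only some of its stereocentres, whereas this pair inverts all of them, and even this complete inversion gives a step no larger than repeated measurements would: the fact that compounds 1 and 4 differ only in the configuration as drawn. Taken together, the two configuration steps give no sign that the arrangement of these ring carbons matters in this read-out at the concentration tested, although with numbers this small and this close, the assay offers little room for any such preference to show.

As far as these compounds go, it remains open whether a methyl ester or an amide in place of the carboxylic acid, or a benzyl group added to the shared core, would bring a compound beyond the scatter of these four. From the compounds shown here alone, it is equally open whether compound 1 and compound 4 would separate in a test against a different enzyme, since a mirror-image difference that stays hidden here might still appear elsewhere.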